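Adding a Third Methoxy Group to the Benzoyl Ester

The source may hold more compounds than are shown below. What is called first, only, known or untested is meant among the compounds shown, and "the series" means these compounds.

Measured compounds in a functional assay on HL-60 cells (Homo sapiens) for cytotoxicity, read by MTT assay, with a stated time of 24 h; on this read-out higher numbers stand for weaker inhibition and lower numbers for stronger inhibition:
compound 1 `COC(=O)/C(=C\c1ccc(OC(=O)c2ccccc2)cc1)Sc1ccnc2cc(Cl)ccc12` gives 30200 nM
compound 2 `COC(=O)/C(=C\c1ccc(OC(=O)c2ccc(OC)c(OC)c2)cc1)Sc1ccnc2cc(Cl)ccc12` gives 5290 nM
compound 3 `COC(=O)/C(=C\c1ccc(OC(=O)c2c(OC)cccc2OC)cc1)Sc1ccnc2cc(Cl)ccc12` gives 37200 nM

Compound 3 stands with the highest number of the three in this assay. Its nearest neighbour is compound 1, and the step of a 1.2-fold higher number from compound 1 to compound 3 (0.09 log units; within the scatter) lies within the scatter, so the two cannot be ordered. The step of a 7.0-fold higher number from compound 2 to compound 3 (0.85 log units; beyond the scatter) is beyond the scatter and separates compound 3 clearly from compound 2.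

Compound 4 `COC(=O)/C(=C\c1ccc(OC(=O)c2cc(OC)c(OC)cc2OC)cc1)Sc1ccnc2cc(Cl)ccc12` differs from compound 3 in one place: 2,4,5-trimethoxyphenyl in place of 2,6-dimethoxyphenyl on a carbonyl carbon. Among the compounds with values here, two measured steps bear on this, both changing the methoxy pattern on the same ring. The step of a 5.7-fold lower number from compound 1 to compound 2 (0.76 log units; beyond the scatter) shows that a 3,4-dimethoxyphenyl gave a lower number than plain phenyl, while a 7.0-fold higher number from compound 2 to compound 3 (0.85 log units; beyond the scatter) shows that the 2,6-dimethoxyphenyl pattern gave the number back up. Within the data shown here, the entering 2,4,5-trimethoxyphenyl carries methoxy groups at positions named in that group, but no measured step covers this group itself, so the expectation is uncertain.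

Compound 4 is therefore expected to give about 12000 nM, with a range from 3000 nM to 45000 nM. This estimate means a step of a 3.1-fold lower number from compound 3 to compound 4 (0.49 log units; beyond the scatter), expected toward a lower number in this assay.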

Compound 4, half-maximal inhibitory concentration: 6260 nM
Beside the measured number, compound 4's estimate is 1.9-fold (0.28 log units) above it, within the range that was stated.
By their numbers in this assay, from the lowest: compounds 2 and 4 (each within the scatter of the next); then compounds 1 and 3 (each within the scatter of the next).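

On this assay, the 2,4,5-trimethoxyphenyl group on this carbonyl carbon gives a clear drop from the 2,6-dimethoxyphenyl group (a 5.9-fold lower number from compound 3 to compound 4 (0.77 log units; beyond the scatter)) and from plain phenyl (a 4.8-fold lower number from compound 1 to compound 4 (0.68 log units; beyond the scatter)), so a methoxy-bearing ring here need not stay with compound 1 and compound 3 at the high end of the series. The further methoxy in place of hydrogen on an aromatic carbon adds nothing that can be resolved, since the step from the 3,4-dimethoxyphenyl group (a 1.2-fold higher number from compound 2 to compound 4 (0.07 log units; within the scatter)) lies within the scatter, and compound 2 and compound 4 cannot be ordered. Nothing in the available information accounts for why the methoxy patterns on this ring part in this way.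

The compounds shown leave open whether the lower numbers depend on methoxy itself or would also appear with a hydroxy group, a fluorine or an amine on the same ring. They also leave open whether a benzoyl ring carrying a single methoxy group would already sit with compound 2 and compound 4 on this assay, or whether an amide in place of the ester link would keep these numbers.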